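Benzothiazolyl to triazolyl thioether on the anilide chain

The compounds below may be only part of what the source reports. "The series", "measured", "known", "first", "only" and "open" are said of these compounds alone.

Measured so far in a functional assay on HT-29 cells (Homo sapiens) for cytotoxicity, read by MTT assay, with a stated time of 24 h, tested at 32 ug/mL; a lower number here means a weaker effect, a higher number a stronger effect of the compound at the concentration tested:
compound 1 `Cn1c(-c2ccc(NC(=O)CCl)cc2)nc(-c2ccccc2)c1-c1ccccc1`, 53.2%
compound 2 `Cn1c(-c2ccc(NC(=O)CSc3nc4ccccc4s3)cc2)nc(-c2ccccc2)c1-c1ccccc1`, 66%

Compound 2 stands highest of the two numbers in this assay; its nearest neighbour is compound 1, which sits lower by a number 12.8 percentage points higher from compound 1 to compound 2 (beyond the scatter), a step beyond the scatter. Among the measured compounds shown here, that single step, (1,3-benzothiazol-2-yl)sulfanyl in place of chloro on a saturated chain carbon bound to a carbonyl carbon, is the only measured change.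

Compound 3 `Cn1cnnc1SCC(=O)Nc1ccc(-c2nc(-c3ccccc3)c(-c3ccccc3)n2C)cc1` is not yet measured. It differs from compound 2 as follows: 4-methyl-4H-1,2,4-triazol-3-yl in place of 1,3-benzothiazol-2-yl on a sulfur. The step from compound 1 to compound 2 is the only one that touches this part of the molecule, and it shows that attaching an aromatic thioether at this carbon raised the read-out modestly; nothing measured shows how the read-out answers an exchange of one aromatic group on the sulfur for another. The expectation is therefore a number near compound 2, with a step of about a number 10 percentage points lower from compound 2 to compound 3 (within the scatter) that may well fall within the scatter. Compound 3 is estimated at 56%, with a range from 42% to 70%.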

Compound 3, a percentage reported as activity, at one concentration (the size of the read-out at that concentration, not a potency): 86.1%
Compound 3: the middle estimate sits 30.1 percentage points below what was measured; measured number above the stated range.
By their numbers in this assay, from the lowest: compound 1; then compound 2; then compound 3.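

In this assay, the group on the sulfur matters in its own right: 4-methyl-4H-1,2,4-triazol-3-yl in place of 1,3-benzothiazol-2-yl gives a number 20.1 percentage points higher from compound 2 to compound 3 (beyond the scatter) and makes compound 3 the highest of the three compounds, so the read-out answers an exchange of one aromatic group on the sulfur for another. Among the compounds shown here, measured against the chloro starting point, (4-methyl-4H-1,2,4-triazol-3-yl)sulfanyl gives a number 32.9 percentage points higher from compound 1 to compound 3 (beyond the scatter) and is the only step rated large, so a thioether at this chain carbon can do much more than the first example showed. The higher number here belongs to the entering group with one ring and 6 heavy atoms rather than the leaving group with two rings and 9 heavy atoms, but no measurement available accounts for this difference.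

A single pair cannot separate the loss of the six-membered ring from the change in ring nitrogens or the methyl on the triazole. A phenyl or a 4-ethyl-4H-1,2,4-triazol-3-yl on the sulfur, or a longer chain in place of the saturated chain carbon, would test how far the gain extends, and the read-out shows only a stronger or weaker effect at the one concentration tested.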